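Moving a Branch Along an Alkyl Chain

This account rests on a few compounds, and the source may have more. Where it says the series, first, only, none or still open, it means among the compounds named here.

Three compounds that share a core and differ only in the alkyl chain carried on the double-bonded nitrogen were dosed in a functional assay on the whole organism (blood, strain Wistar-Okamoto) with Rattus norvegicus as the target, with a stated time of 5 days; a higher number here means that more compound is needed for the effect, a lower number that less compound is needed. Compound 1 `CCCCC/N=C(\NC#N)Nc1cccnc1` carries a pentyl chain, and in this assay compound 1 gives 20 mg/kg. Compound 2 `CC(C)CC/N=C(\NC#N)Nc1cccnc1` carries an isopentyl chain, and in this assay compound 2 gives 20 mg/kg. The difference between them is isopropyl in place of propyl on a saturated chain carbon, two bonds along the chain from a double-bonded nitrogen, and it leaves the dose where it was: no change at the digits printed from compound 1 to compound 2 (within the scatter). Compound 3 `CCCC(C)(C)/N=C(\NC#N)Nc1cccnc1` carries a 1,1-dimethylbutyl chain, and in this assay compound 3 gives 1 mg/kg, the lowest of the three doses; against compound 1 the step is a 20-fold lower number from compound 1 to compound 3 (1.30 log units; beyond the scatter), and against compound 2 it is a 20-fold lower number from compound 2 to compound 3 (1.30 log units; beyond the scatter). The core of compound 3 differs from that of compound 1 by 1,1-dimethylbutyl in place of pentyl on a double-bonded nitrogen.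

Compound 4 `CC(C)C(C)(C)/N=C(\NC#N)Nc1cccnc1` has not yet been dosed. It differs from compound 3 by isopropyl in place of propyl on a saturated chain carbon bound to a double-bonded nitrogen and two saturated chain carbons. Going by the values given here, this is the same kind of change as the one from compound 1 to compound 2, but not the same: there the place was a saturated chain carbon two bonds along the chain from a double-bonded nitrogen, here it is a saturated chain carbon bound to a double-bonded nitrogen and two saturated chain carbons. The step from compound 3 to compound 4 is expected to be small, a 1.5-fold higher number from compound 3 to compound 4 (0.18 log units; within the scatter), because the same kind of change gave no change at the digits printed from compound 1 to compound 2 (within the scatter). Among the compounds with values here, no measured pair shows a branch this close to the double-bonded nitrogen being moved, so the range is kept wide. In this assay compound 4 is expected to give about 1.5 mg/kg, between 0.5 mg/kg and 5 mg/kg.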

Compound 4, minimum effective dose: 1 mg/kg
Compound 4: middle estimate off by 1.5-fold (0.18 log units), on the high side; the measured number falls inside the stated range.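

In this assay moving from propyl to isopropyl at this new place gives no change at the digits printed from compound 3 to compound 4 (within the scatter), so the change that left the dose untouched on the core of compound 1 also leaves it untouched on the core of compound 3, and the two results agree: the same change on two cores in this assay, no change at the digits printed (within the scatter) from compound 1 to compound 2 and no change at the digits printed (within the scatter) from compound 3 to compound 4, 1.0-fold (0.00 log units) apart, within the scatter of two such steps. The large steps stay in place, with a 20-fold lower number from compound 2 to compound 4 (1.30 log units; beyond the scatter) and a 20-fold lower number from compound 1 to compound 4 (1.30 log units; beyond the scatter), so the 1,1,2-trimethylpropyl chain of compound 4 stands with the 1,1-dimethylbutyl chain of compound 3, well apart from the pentyl and isopentyl chains. Going by these compounds alone, this agreement rests on only two pairs in this assay, it says nothing about a third core, and since the change sits at a different place on the chain in each pair, it cannot separate the effect of the core from the effect of the place.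

The compounds shown leave open whether other chains, such as tert-butyl, a longer chain or a cyclohexyl group, would stay with compound 3 and compound 4 or fall back towards compound 1 and compound 2. They also leave open what would happen if the nitrile were replaced by a carboxamide while the chain stayed the same.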